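Swapping a Fluorinated Chain for a Branched One

This account rests on a few compounds, and the source may have more. Where it says the series, first, only, none or still open, it means among the compounds named here.

Compound 1 `O=c1n(Cc2nc3nc(Cl)ccc3n2CCCCF)c2cnccc2n1C1CC1`: > 50000 nM
Compound 2 `COc1ccc(-n2c(=O)n(Cc3cc4cc(Cl)ccc4n3CCCC#N)c3cnccc32)c(F)c1`: > 50000 nM
Compound 3 `N#CCCCn1c(Cn2c(=O)n(-c3ccncn3)c3ccncc32)cc2cc(Cl)ccc21`: > 50000 nM

In an ADME assay on HeLa cells (Homo sapiens) for cytotoxicity, read by ATP content, with a stated time of 3 days (a higher number here means that more compound is tolerated, a lower number that less compound is tolerated), compound 1 gives a limit of the assay rather than a number. The same holds for compound 2. It holds for compound 3 as well. Compound 1 therefore stands at the limit, and nothing in these numbers separates it from the other two. Going by the values given here, the only step with both ends measured, a step that the two limits leave unreadable from compound 2 to compound 3, runs between two limits and gives no readable size.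

Compound 4 `CC(C)CCn1c(Cn2c(=O)n(C3CC3)c3ccncc32)nc2nc(Cl)ccc21` differs from compound 1 by isopropyl in place of 2-fluoroethyl on a saturated chain carbon, two bonds along the chain from an aromatic nitrogen. Among the compounds with values here, no measured step touches this chain, so no step size can be carried over. Because the limit of > 50000 nM in this assay, at which 3 of the 3 values shown sit, is where every value shown sits, compound 4 is expected to reach the limit as well. Compound 4 is estimated at 50000 nM, with a range from 25000 nM to 100000 nM. The expected step is a number no higher from compound 1 to compound 4 (the limit leaves the size open), none beyond the scatter.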

Compound 4, half-maximal cytotoxic concentration: > 50000 nM
Compound 4: a limit, no number; the forecaster's own chance of this, stated with the estimate: 85%; the middle value sits exactly at the limit.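

Going by these compounds alone, compound 1 and compound 4 both give only a limit of the assay, so putting isopropyl in place of 2-fluoroethyl yields no step that can be read. The compounds shown leave open at what concentration any of them harms these cells, and whether any structural change shifts it, since all share one end point: the limit of > 50000 nM in this assay, at which 4 of the 4 values shown sit.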